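Methoxy for chloro in the aryl hydrazone of compound 2

The compounds below may be only part of what the source reports. "The series", "measured", "known", "first", "only" and "open" are said of these compounds alone.

Measured so far:
compound 1, `COc1cccc(/C=N/NC(=O)c2cccnc2Nc2cccc(C(F)(F)F)c2)c1`: 52.8%
compound 2, `CNc1ncccc1C(=O)N/N=C/c1cccc(Cl)c1`: 67.1%

In a functional assay on the whole organism (strain Wistar) for inhibition, with Rattus norvegicus as the target, read by paw edema, with a stated time of 30 min, at a dose of 10 mg/kg by the intraperitoneal route (on this read-out lower numbers stand for less inhibition and higher numbers for more inhibition at the one dose given (going by the name of the read-out)), compound 2 gives 67.1%, the highest of the two numbers; compound 1 gives 52.8%, a gap beyond the scatter. Compound 3, `CNc1ncccc1C(=O)N/N=C/c1cccc(OC)c1`, is unmeasured and differs from compound 2 in one place: methoxy in place of chloro on an aromatic carbon. Going by the values given here, no measured pair shows this change alone; compound 1 also carries methoxy but differs from compound 2 elsewhere too, so it gives only a loose hint of a lower number. The expected step is a number 9.1 percentage points lower from compound 2 to compound 3 (within the scatter), a small fall near the edge of the scatter. Compound 3 is estimated at 58%, range 42% to 72%.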

Compound 3, a percentage reported as inhibition, in the whole organism at one dose (the size of the read-out at that dose, not a potency): 56.1%
Estimate against measurement, compound 3: 1.9 percentage points above; measured number inside the range.
By their numbers in this assay, from the lowest: compounds 1 and 3 (each within the scatter of the next); then compound 2.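

In this assay, methoxy in place of chloro on the aromatic carbon can now be read alone: a number 11 percentage points lower from compound 2 to compound 3 (beyond the scatter), so the two groups are not interchangeable at this position. With methoxy held constant, methyl in place of 3-(trifluoromethyl)phenyl on the nitrogen gives a number 3.3 percentage points higher from compound 1 to compound 3 (within the scatter), so this change does not separate the pair. Nothing available explains either step.

The compounds shown leave open whether fluoro, hydroxyl or an amine on this carbon would read nearer compound 2 or compound 3. Also open, as far as these compounds go, is whether 3-(trifluoromethyl)phenyl on the nitrogen would read the same alongside chloro.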